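The source may report more compounds than this note shows. Statements on the series, on what has been measured and on what is new or still open speak of the compounds shown alone.

Measured so far in an ADME assay on HEL cells (Homo sapiens) for cytotoxicity; on this read-out lower numbers stand for higher toxicity in this test and higher numbers for lower toxicity in this test:

compound 1, `Cc1ccccc1OCCCCCn1ccc(=O)[nH]c1=O`, > 100000 nM.
compound 2, `CC(C)(C)c1ccc(OCCCCCn2ccc(=O)[nH]c2=O)cc1`, 40000 nM.
compound 3, `O=c1ccn(CCCCCOc2ccc(Cl)cc2)c(=O)[nH]1`, "not determined" (no result reported).

The value of compound 1 is a limit of the assay, not a number. Compound 2 gives a number. Compound 3 has no number at all, so it cannot be placed among the others; the only fixed point is the limit of > 100000 nM in this assay, at which 1 of the 3 values shown sits, which compound 1 reaches. Compound 4, `O=c1ccn(CCCCCOc2ccc(Br)cc2)c(=O)[nH]1`, differs from compound 3 in one place: bromo in place of chloro on an aromatic carbon. Among the measured compounds shown here, no step between two measured compounds exists here, so there is nothing to say about its size; a change of this kind is not expected to move the read-out beyond the usual scatter. For compound 4 the estimate in this assay is 60000 nM, between 20000 nM and 200000 nM.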

Compound 4, half-maximal cytotoxic concentration: > 100000 nM
Compound 4 gave a limit, no number (the forecaster's own chance of this, stated with the estimate: 45%); middle value at least 1.6-fold (0.22 log units) from the limit.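

In this assay bromo in place of tert-butyl gives an at least 2.5-fold higher number from compound 2 to compound 4 (0.39 log units; beyond the scatter) and so lower toxicity in this test, the first readable effect of changing the group at this position. Compound 4 gives a limit and not a number, and it is the second compound to do so: the limit of > 100000 nM in this assay, at which 2 of the 4 values shown sit. The step between compound 1 and compound 4 cannot be read, as both values are limits.

As far as these compounds go, how an amine or a carboxylic acid in place of bromo would read stays open. So does the standing of compound 3, with its chloro, which has no result.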